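Crotonamide in place of acrylamide on the cyano analogue

The source may report more compounds than this note shows. Statements on the series, on what has been measured and on what is new or still open speak of the compounds shown alone.

Two members of the series have been measured. Compound 1 `C/C=C/C(=O)Nc1cccc(Oc2nc(Nc3cccc(OC)c3)nc3ccsc23)c1` carries a methoxy group on the anilino ring and a prop-1-en-1-yl carbonyl on the amide; in a functional assay on HeLa cells (Homo sapiens) for inhibition, read by MTT assay, with a stated time of 72 h (a lower number here means a stronger inhibitor, a higher number a weaker inhibitor), compound 1 gives 20100 nM. Compound 2 `C=CC(=O)Nc1cccc(Oc2nc(Nc3cccc(C#N)c3)nc3ccsc23)c1` carries a nitrile on the anilino ring and a vinyl carbonyl on the amide; in this assay compound 2 gives 6390 nM, the lower of the two numbers, with compound 1 standing beyond the scatter above it. The two compounds differ in two places at once, so no single step can be read from them.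

Compound 3 `C/C=C/C(=O)Nc1cccc(Oc2nc(Nc3cccc(C#N)c3)nc3ccsc23)c1` is the next member. Relative to compound 2 the change is prop-1-en-1-yl in place of vinyl on a carbonyl carbon; the nitrile is retained. Among the compounds with values here, no measured pair isolates this change, so the expectation rests on compound 2 alone. A modest shift toward weaker inhibition is expected, of a size a 1.6-fold higher number from compound 2 to compound 3 (0.19 log units; within the scatter), though a result within the scatter of compound 2 would not be surprising. For compound 3 the estimate in this assay is 10000 nM, with a range from 4000 nM to 30000 nM.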

Compound 3, half-maximal inhibitory concentration: 23600 nM
Compound 3: the middle estimate sits 2.4-fold (0.37 log units) below what was measured; low and high end bracket the measured number.
By their numbers in this assay, from the lowest: compound 2; then compounds 1 and 3 (each within the scatter of the next).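

In this assay, within the data shown here, the position on the carbonyl carbon of the amide proves sensitive to a small change: prop-1-en-1-yl in place of vinyl gives a 3.7-fold higher number from compound 2 to compound 3 (0.57 log units; beyond the scatter) and, with the nitrile held constant, this is the first step that can be read in one place, and it favours vinyl. With prop-1-en-1-yl held on the amide, cyano in place of methoxy on an aromatic carbon gives a 1.2-fold higher number from compound 1 to compound 3 (0.07 log units; within the scatter), so on this amide the swap of these two groups does not separate compound 1 from compound 3 in this cell read-out. Nothing measured on these compounds accounts for either step.

On these data alone, whether the vinyl to prop-1-en-1-yl step keeps its size with methoxy in place of the nitrile remains open, as does whether the aromatic swap stays within the scatter on the vinyl amide. Also open, as far as these compounds go, is how the amide position responds to other groups on the carbonyl carbon, such as a dimethylaminomethyl-substituted vinyl group, a longer alkenyl chain or a saturated ethyl group.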